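A few compounds are considered here, and "the series" means these few. Any claim that something is new, unique, unknown or untested is made for them only; others in the source may bear on it.

Within the data shown here, compound 1, whose structure is `CC1=C(/C=C/C(=O)/C=C/c2ccccc2)C(C)(C)CCC1O`, is the one member of this small set for which a number stands. In a functional assay on LNCaP C4-2B cells (Homo sapiens) for cytotoxicity, read by MTT assay, with a stated time of 72 h (a higher number here means a weaker inhibitor, a lower number a stronger inhibitor), compound 1 gives 1800 nM. Among the measured compounds shown here, a second compound, compound 2 with the structure `CC1=C(/C=C/C(=O)/C=C/c2ccccc2C(F)(F)F)C(C)(C)CCC1O`, belongs to the same series, but in this assay compound 2 gives "not determined" (no result reported), so it offers no number to compare against and no step between measured compounds can be drawn from these two.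

The unmeasured compound of interest is compound 3, with the structure `CC1=C(/C=C/C(=O)/C=C/c2cccc(C(F)(F)F)c2)C(C)(C)CCC1O`. It differs from compound 1 in one place: trifluoromethyl in place of hydrogen on an aromatic carbon. For the measured compounds named here, since no measured step of this kind is available here, the expectation for compound 3 rests on the single value of compound 1 and on the nature of the change alone. The author expects the step from compound 1 to compound 3 to be small, at most a modest gain in potency that may well lie within the scatter, a 1.5-fold lower number from compound 1 to compound 3 (0.18 log units; within the scatter). For compound 3 the estimated result is therefore 1200 nM, with a range from 400 nM to 4000 nM.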

Compound 3, half-maximal inhibitory concentration: 1400 nM
For compound 3 the middle estimate is 1.2-fold (0.07 log units) below the measured one; low and high end bracket the measured number.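

In this assay, among these compounds, trifluoromethyl in place of hydrogen on an aromatic carbon of the six-membered aromatic ring, meta to a large group, gives a 1.3-fold lower number from compound 1 to compound 3 (0.11 log units; within the scatter), and this is the first step that can be read in this small set. It shows that, at this one place and in this one cell assay, a substituent of four heavy atoms can replace a hydrogen while compound 3 stays indistinguishable from compound 1 within the usual scatter, so the activity of compound 1 is kept rather than lost. The compounds shown offer no measurement that would explain this outcome.

Compound 2, which carries trifluoromethyl at a different place on the same ring, has no reported result, so any step involving it cannot be read and the data do not show whether the place of the group matters. Going by these compounds, it also remains open how an amine, a carboxylic acid or a methoxy group at the place of the trifluoromethyl in compound 3 would behave in this assay, since this single step describes only one substituent at one place.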